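A Smaller Group in Place of Benzylsulfanyl

A few compounds are considered here, and "the series" means these few. Any claim that something is new, unique, unknown or untested is made for them only; others in the source may bear on it.

Measured so far:
- compound 1, `CCCSc1nnc(Cc2ccc(Cl)cc2Oc2ccccc2F)[nH]1`: 127%
- compound 2, `Fc1ccccc1Oc1cc(Cl)ccc1Cc1nnc(SCc2ccccc2)[nH]1`: 169%

Among the compounds with values here, in a functional assay on the whole organism (strain NMRI) with Mus musculus as the target, with a stated time of 60 min, at a dose of 10 mg/kg by the intraperitoneal route (a higher number here means a stronger effect of the compound at the dose given, a lower number a weaker effect), compound 2 gives 169%, the higher of the two numbers measured so far. Its nearest neighbour is compound 1, which in this assay gives 127%. Within the data shown here, the one measured step, a number 42 percentage points higher from compound 1 to compound 2 (beyond the scatter), changes only the group on the sulfur and is well beyond the scatter.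

Compound 3, `CCOc1nnc(Cc2ccc(Cl)cc2Oc2ccccc2F)[nH]1`, is not yet measured. It differs from compound 2 in one place: ethoxy in place of benzylsulfanyl on an aromatic carbon. So the group that grew from ethyl to phenyl in the measured step is removed altogether, and the sulfur gives way to an oxygen on the same aromatic carbon of the five-membered ring. The measured step suggests that losing the phenyl costs activity, but nothing measured tells how the oxygen for sulfur exchange acts, so the expectation rests on one step only.

The expected step is therefore downward, a number 49 percentage points lower from compound 2 to compound 3 (beyond the scatter), and compound 3 is estimated at 120%, with a range from 80% to 165%.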

Compound 3, a percentage reported as activity, at one dose (the size of the read-out at that dose, not a potency): 116%
The estimate for compound 3 lay 4 percentage points above the measured number, and the stated range covers the measured number.
By their numbers in this assay, from the lowest: compound 3; then compound 1; then compound 2.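

In this assay the full exchange of benzylsulfanyl for ethoxy gives a number 53 percentage points lower from compound 2 to compound 3 (beyond the scatter) and removes the aromatic ring from the group, which leaves the benzylsulfanyl compound on top of the three shown. Set against propylsulfanyl, the same ethoxy group gives a number 11 percentage points lower from compound 1 to compound 3 (beyond the scatter) so two groups without a ring end up only a modest distance apart even though one is attached through sulfur and the other through oxygen, but this step changes the chain and the linking atom together and cannot divide the effect between them. Nothing available explains why the numbers differ in this way.

As far as these compounds go, the separate contribution of the linking atom remains open: propoxy would pair directly with propylsulfanyl, and benzyloxy with benzylsulfanyl, so that only oxygen and sulfur differ in each pair. Also open, from the compounds shown here alone, is whether the attachment needs to be through either of these atoms at all, which an amine bearing a benzyl group on the same aromatic carbon would begin to test.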